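A few compounds are considered here, and "the series" means these few. Any claim that something is new, unique, unknown or untested is made for them only; others in the source may bear on it.

Three urea compounds share one core and differ only in the five-membered ring carried on the benzyl group. In an assay on microsomes from intestine for inhibition of acyl-CoA:cholesterol acyltransferase (Oryctolagus cuniculus) (a lower number here means a stronger inhibitor, a higher number a weaker inhibitor), compound 1 `Cc1cc(C)c(NC(=O)N(Cc2ccc(-c3n[nH]c(C)n3)cc2)C2CCCCCC2)c(C)c1` gives 120 nM, compound 2 `Cc1cc(C)c(NC(=O)N(Cc2ccc(-c3cc[nH]n3)cc2)C2CCCCCC2)c(C)c1` gives 52 nM, and compound 3 `Cc1cc(C)c(NC(=O)N(Cc2ccc(-c3ccnn3C)cc2)C2CCCCCC2)c(C)c1` gives 24 nM, the lowest of the three numbers. Compound 4 `Cc1cc(C)c(NC(=O)N(Cc2ccc(-n3nccn3)cc2)C2CCCCCC2)c(C)c1` has not yet been measured; it carries 2H-1,2,3-triazol-2-yl in place of 1-methyl-1H-pyrazol-5-yl on an aromatic carbon. For the measured compounds named here, two measured steps bear on this change, a 5.0-fold lower number from compound 1 to compound 3 (0.70 log units; beyond the scatter) and a 2.2-fold lower number from compound 2 to compound 3 (0.34 log units; beyond the scatter), each swapping a ring with a hydrogen on nitrogen for one without. Going by the values given here, the ring of compound 4, like that of compound 3, carries no such hydrogen, but it is joined through nitrogen rather than carbon, which no measured pair covers. The expected step of a 1.5-fold higher number from compound 3 to compound 4 (0.16 log units; within the scatter) is therefore small, at most slightly weaker. Compound 4 is estimated at 35 nM, with a range from 12 nM to 110 nM.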

Compound 4, half-maximal inhibitory concentration: 130 nM
Compound 4: the middle estimate sits 3.7-fold (0.57 log units) below what was measured; measured number outside the range, above it.
By their numbers in this assay, from the lowest: compound 3; then compound 2; then compounds 1 and 4 (each within the scatter of the next).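

Having no hydrogen on a ring nitrogen is not enough to keep the number low at this position: this assay shows a 5.4-fold higher number from compound 3 to compound 4 (0.73 log units; beyond the scatter) even though neither ring carries one. The 2H-1,2,3-triazol-2-yl ring also does worse than a ring with such a hydrogen, with a 2.5-fold higher number from compound 2 to compound 4 (0.40 log units; beyond the scatter) and a 1.1-fold higher number from compound 1 to compound 4 (0.03 log units; within the scatter) as the other two steps. No measurement here explains these differences.

The change alters the linking atom, the ring nitrogens and the methyl together, so their shares remain unseparated. A 1H-pyrazol-1-yl or 1-methyl-1H-1,2,3-triazol-5-yl ring would help to separate them.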